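Swapping a sulfonyl for a carbonyl on compound 2

The compounds below may be only part of what the source reports. "The series", "measured", "known", "first", "only" and "open" are said of these compounds alone.

Values so far in a physicochemical assay for lipophilicity, at pH 7.4 (a higher number here means a more lipophilic compound, a lower number a more polar compound), for three compounds:
Compound 1 `Cc1ccc(N(CC(C)C)S(=O)(=O)c2ccc3c(c2)C(=O)CC(C2CCOCC2)O3)c(C)c1` gives 4.28
Compound 2 `CCc1ccc(N(CC(C)C)S(=O)(=O)c2ccc3c(c2)C(=O)CC(C2CCN(S(=O)(=O)C4CCCC4)CC2)O3)cc1` gives 4.75
Compound 3 `CC(C)CN(c1ccc(C(C)(C)C)cc1)S(=O)(=O)c1ccc2c(c1)C(=O)CC(C1CCOCC1)O2` gives 4.97

Compound 2 (4.75) lies within the usual scatter of compound 3 (4.97). Measured against compound 1 (4.28), compound 2 stands higher by more than that scatter. The next compound to be measured is compound 4 `CCc1ccc(N(CC(C)C)S(=O)(=O)c2ccc3c(c2)C(=O)CC(C2CCN(C(=O)C4CCCC4)CC2)O3)cc1` and it keeps almost all of compound 2. Cyclopentylcarbonyl stands in place of cyclopentylsulfonyl on an amine nitrogen in a ring (cyclopentylcarbonyl in place of cyclopentylsulfonyl on an amine nitrogen in a ring). Both groups carry the same five-membered non-aromatic ring of carbon only.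

Among the measured compounds shown here, only one measured step is available (a number 0.69 log units higher from compound 1 to compound 3 (beyond the scatter)). It puts 4-(tert-butyl)phenyl in place of 2,4-dimethylphenyl on a sulfonamide nitrogen, which is a different place in the molecule. For the measured compounds named here, it therefore offers no direct guide, and no measured pair shows this swap. The expectation has to start from compound 2 (4.75) and assume that little moves. The change expected in this assay is an estimated a number 0.10 log units lower from compound 2 to compound 4 (within the scatter) and so none beyond the scatter, with the direction left uncertain. For compound 4 the estimated value is 4.65 (expected range 4.2 to 5.1).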

Compound 4, distribution coefficient: 5.13
Compound 4: the middle estimate sits 0.48 log units below what was measured; measured number above the stated range.
By their numbers in this assay, from the lowest: compound 1; then compounds 2, 3 and 4 (each within the scatter of the next, the first and the last beyond it).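

Among the compounds shown here, this pair is the first measured change on the amine nitrogen of the six-membered non-aromatic ring, and it shows that the group there can move the reading in this assay by more than the scatter (the step is a number 0.38 log units higher from compound 2 to compound 4 (beyond the scatter)). Both groups carry the same five-membered non-aromatic ring of carbon only, so the difference lies in the link to the nitrogen: cyclopentylsulfonyl has 8 heavy atoms and 2 hydrogen-bond acceptors, and cyclopentylcarbonyl has 7 heavy atoms and 1 hydrogen-bond acceptor. The data show the size and direction of this step, but nothing measured here accounts for it.

This single pair leaves open whether the swap gives a similar step with other groups on that nitrogen, such as acetyl against methylsulfonyl, or a phenyl ring in place of the cyclopentyl ring. It also leaves open whether the step holds when 2,4-dimethylphenyl or 4-(tert-butyl)phenyl sits on the sulfonamide nitrogen, or when a longer chain replaces the group there.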